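Moving the Methyl on the Phenoxy Ring

The source may report more compounds than this note shows. Statements on the series, on what has been measured and on what is new or still open speak of the compounds shown alone.

Compound 2 `CCCCCNC(=O)NS(=O)(=O)c1cc(C#N)ccc1Oc1ccccc1C` stands lowest of the two numbers measured in a functional assay on HEK293 cells for antagonist activity at thromboxane A2 receptor (Homo sapiens), read by fluorescence and calcium flux; a higher number here means a weaker inhibitor, a lower number a stronger inhibitor: compound 2 gives 1780 nM, whereas compound 1 `Cc1ccccc1Oc1ccc(C#N)cc1S(=O)(=O)NC(=O)NC(C)C` gives 6130 nM. Within the data shown here, the only measured step, a 3.4-fold lower number from compound 1 to compound 2 (0.54 log units; beyond the scatter), concerns the chain on the amide-type nitrogen and leaves the aryl ether untouched. Compound 3 `CCCCCNC(=O)NS(=O)(=O)c1cc(C#N)ccc1Oc1cccc(C)c1` keeps the pentyl chain of compound 2 and differs from it only in the ring on the oxygen: 3-methylphenyl in place of 2-methylphenyl on an oxygen on an aromatic ring. Among the measured compounds shown here, no measured step bears on this part of the molecule, so the data give no direction for the change, and the step is expected to stay within the scatter. For compound 3 the value in this assay is therefore estimated at 1800 nM, with a range from 600 nM to 5500 nM. That estimate corresponds to an expected step of a 1.0-fold higher number from compound 2 to compound 3 (0.00 log units; within the scatter).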

Compound 3, half-maximal inhibitory concentration: 680 nM
The estimate for compound 3 lay 2.6-fold (0.42 log units) above the measured number; the measured number falls inside the stated range.
By their numbers in this assay, from the lowest: compound 3; then compound 2; then compound 1.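

The phenoxy ring is a position that responds to change: in this assay, 3-methylphenyl in place of 2-methylphenyl gives a 2.6-fold lower number from compound 2 to compound 3 (0.42 log units; beyond the scatter), with the pentyl chain held constant. Among these compounds, this is the first measured step at this position, and it shows that moving the methyl alone shifts the number beyond the scatter, although the two groups have the same heavy atoms and the same counts of donors and acceptors. Nothing available explains this difference.

On these data alone, it remains open whether an unsubstituted phenyl, or a chlorine or a methoxy group in place of the methyl, would give a lower or higher number. Also open, as far as these compounds go, is whether 3-methylphenyl would have the same effect with the isopropyl chain of compound 1 or with a chain longer than pentyl.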